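A few compounds are considered here, and "the series" means these few. Any claim that something is new, unique, unknown or untested is made for them only; others in the source may bear on it.

Measured so far: compound 1 `COc1ccc2c(c1)c(/C=N/O)cn2Cc1cn([C@@H]2O[C@H](COC(C)=O)[C@@H](OC(C)=O)[C@H](OC(C)=O)[C@H]2OC(C)=O)nn1` with 88400 nM; compound 2 `CC(=O)OC[C@H]1O[C@@H](n2cc(Cn3cc(C(C)=O)c4ccccc43)nn2)[C@H](OC(C)=O)[C@@H](OC(C)=O)[C@@H]1OC(C)=O` with 75200 nM.

Both numbers come from a functional assay on DU-145 cells (Homo sapiens) for cytotoxicity, read by sulforhodamine B assay, with a stated time of 48 h; a lower number here means a stronger inhibitor, a higher number a weaker inhibitor. Compound 1 shows the higher of the two, but compound 2 lies within the usual scatter of it, so no real order between them can be claimed. Compound 3 `COc1ccc2c(c1)c(/C=C1/C(=O)Nc3ccc(F)cc31)cn2Cc1cn([C@@H]2O[C@H](COC(C)=O)[C@@H](OC(C)=O)[C@H](OC(C)=O)[C@H]2OC(C)=O)nn1` has not been measured yet. It differs from compound 1 by a group of 12 heavy atoms (9 carbon, 1 nitrogen, 1 oxygen, 1 fluorine; one five-membered non-aromatic ring with 1 hetero atom, one six-membered aromatic ring of carbon only) in place of a group of 3 heavy atoms (1 carbon, 1 nitrogen, 1 oxygen; no ring), on an aromatic carbon. For the measured compounds named here, no measured pair shows what such a change does here; a moderate step toward a lower number, beyond the scatter, is expected, amounting to an 11-fold lower number from compound 1 to compound 3 (1.04 log units; beyond the scatter). Compound 3 is therefore estimated at about 8000 nM, within a range of 1500 nM to 45000 nM.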

Compound 3, half-maximal inhibitory concentration: > 200000 nM
Compound 3: no number, only a limit; the forecaster's own chance of this, stated with the estimate: 10%; at least 25-fold (1.39 log units) between middle value and limit.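

On this aromatic carbon of the shared core, the large group with its five-membered non-aromatic ring and six-membered aromatic ring, in place of the small group of compound 1, gives an at least 2.2-fold higher number from compound 1 to compound 3 (0.35 log units; beyond the scatter) in this assay. This is the first change shown that moves the number beyond the scatter, and it moves it toward a weaker inhibitor. Compound 3 gives only a limit, not a number, so the full size of the step stays unknown: the limit of > 200000 nM in this assay, at which 1 of the 3 values shown sits.

From the compounds shown here alone, whether a small amine or a carboxylic acid at this place would give a lower number stays open. So does whether any group here can move the number clearly lower at all.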